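Amino in place of chloro on the shared core

The compounds below may be only part of what the source reports. "The series", "measured", "known", "first", "only" and "open" are said of these compounds alone.

Measured so far:
compound 1 `Nc1nn(C(=O)Nc2ccc(Cc3ccccc3)cc2)c2ccccc12` — > 100000 nM
compound 2 `Nc1nn(C(=O)Nc2ccc(Cc3ccccc3)cc2)c2ccc(Cl)cc12` — > 100000 nM

In a functional assay on SK-OV-3 cells (Homo sapiens) for antiproliferative activity, read by sulforhodamine B assay, with a stated time of 48 h (a higher number here means that more compound is tolerated, a lower number that less compound is tolerated), compound 1 gives > 100000 nM, a limit of the assay rather than a number. Compound 2 gives > 100000 nM in this assay, again only a limit. Both values therefore sit at the limit of > 100000 nM in this assay, at which 2 of the 2 values shown sit, and the step that the two limits leave unreadable from compound 1 to compound 2 cannot be read in size or direction. Compound 2 thus stands at the limit, with no number to place it against compound 1.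

Compound 3 `Nc1ccc2c(c1)c(N)nn2C(=O)Nc1ccc(Cc2ccccc2)cc1` differs from compound 2 by amino in place of chloro on an aromatic carbon. Within the data shown here, the only measured step, a step that the two limits leave unreadable from compound 1 to compound 2, is unreadable and so gives no guide to the size of this change in this assay. With nothing pointing to a shift beyond the scatter, compound 3 is expected to remain at or near the limit, which makes the expected step of a number no higher from compound 2 to compound 3 (the limit leaves the size open) essentially flat. The estimate for compound 3 in this assay is 100000 nM, with a range from 30000 nM to 300000 nM.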

Compound 3, concentration lethal to 50% of the cells: 92800 nM
For compound 3 the middle estimate is 1.1-fold (0.03 log units) above the measured one; low and high end bracket the measured number.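

In this assay, among these compounds, compound 3 gives the first real number, where the earlier compounds gave only limits, and this yields an at least 1.0-fold lower number from compound 2 to compound 3 (0.03 log units; that floor lies within the scatter) and an at least 1.0-fold lower number from compound 1 to compound 3 (0.03 log units; that floor lies within the scatter). Both steps are floors, so amino on this aromatic carbon brings the read-out onto the measured scale, but a true size for either change cannot be given beyond the fact that the floors lie within the scatter. The comparison therefore stays one-sided: the limit of > 100000 nM in this assay, at which 2 of the 3 values shown sit.

On these data alone, whether any group on this carbon can move the number clearly beyond the scatter remains open. Methoxy, hydroxyl or a carboxylic acid in the same place would test whether amino is in any way special here.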